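The source may report more compounds than this note shows. Statements on the series, on what has been measured and on what is new or still open speak of the compounds shown alone.

Working notes on the series. Compound 1 `CCOC(=O)CCCCCOc1cccc(CN(C(=O)c2ccc(-c3cccc(OCC(C)C)c3)cc2)C(C)C)c1` carries isobutoxy on an aromatic carbon of the shared core. In an ADME assay on HEK293 cells (Homo sapiens) for cytotoxicity, read by CellTiter-Glo and resazurin assay, with a stated time of 72 h (on this read-out higher numbers stand for an effect only at larger amounts of compound and lower numbers for an effect already at smaller amounts), compound 1 gives only a limit of the assay, > 26000 nM. Compound 2 `CCOC(=O)CCCCCOc1cccc(CN(C(=O)c2ccc(-c3cccc(C(F)(F)F)c3)cc2)C(C)C)c1` carries trifluoromethyl in that place. In this assay compound 2 also gives only a limit, > 26000 nM. The step from compound 1 to compound 2 is a step that the two limits leave unreadable from compound 1 to compound 2 because both values sit at the limit of > 26000 nM in this assay, at which 2 of the 2 values shown sit. Compound 2 therefore stands only at a limit, with no number to set it against any other compound. Compound 3 `CCOC(=O)CCCCCOc1cccc(CN(C(=O)c2ccc(-c3cccc(S(C)(=O)=O)c3)cc2)C(C)C)c1` brings the next change: methylsulfonyl in place of trifluoromethyl on an aromatic carbon. Among the compounds with values here, no measured step is readable, so no step in this assay beyond the scatter is expected, and compound 3 is expected to sit at the same limit, an estimated step of a number no higher from compound 2 to compound 3 (the limit leaves the size open). The estimate for compound 3 is 26000 nM, within a range of 13000 nM to 52000 nM.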

Compound 3, half-maximal effective concentration: > 26000 nM
Compound 3 was reported as a limit (the forecaster's own chance of this, stated with the estimate: 85%); the middle value sits exactly at the limit.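

Compound 3 joins compound 1 and compound 2 at a limit, so the steps among these three compounds cannot be read: the limit of > 26000 nM in this assay, at which 3 of the 3 values shown sit. With no number from any of the three, the compounds shown leave open whether this assay separates isobutoxy, trifluoromethyl and methylsulfonyl at all.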